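This account rests on a few compounds, and the source may have more. Where it says the series, first, only, none or still open, it means among the compounds named here.

Measured so far:
compound 1, `CC(C)(C)OC(=O)Nc1ncc(C(Oc2ccc(Br)cc2)c2ccc(Cl)cc2)s1`: > 50000 nM
compound 2, `CC(C)(C)OC(=O)Nc1ncc(C(Oc2ccc(OCc3ccccc3)cc2)c2ccc(Cl)cc2)s1`: > 50000 nM
compound 3, `CC(C)(C)C(=O)Nc1ncc(C(Oc2ccc3cc(Br)ccc3c2)c2ccc(Cl)cc2)s1`: "not toxic" (no number reported)

All three were tested in an ADME assay on HepG2 2.2.15 cells (Homo sapiens) for cytotoxicity; on this read-out higher numbers stand for lower toxicity in this test and lower numbers for higher toxicity in this test. For compound 1 the result is a limit of the assay, > 50000 nM. For compound 2 the result is likewise a limit, > 50000 nM. Compound 3 is reported as "not toxic" (no number reported), with no number attached, so it stands at no point of its own on the scale. Going by the values given here, the only step between two measured compounds, a step that the two limits leave unreadable from compound 1 to compound 2, has both of its ends at a limit, and its size cannot be read. the limit of > 50000 nM in this assay, at which 2 of the 3 values shown sit, marks where those two values sit.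

Compound 4, `O=C(Nc1ncc(C(Oc2ccc3cc(Br)ccc3c2)c2ccc(Cl)cc2)s1)c1ccc(F)cc1Br`, is not yet measured in this assay. It differs from compound 3 in one place: 2-bromo-4-fluorophenyl in place of tert-butyl on a carbonyl carbon. Among the compounds with values here, no measured step involves this change, and the one step that exists gives no readable size. There is therefore no ground to expect a step beyond the scatter in either direction; the most that can be said is that every result shown so far is a limit or a qualitative report. Compound 4 is expected to come out at about 50000 nM, within a range from 15000 nM to 100000 nM, most probably again as a limit.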

Compound 4, half-maximal cytotoxic concentration: > 50000 nM
Compound 4: a limit, no number (the forecaster's own chance of this, stated with the estimate: 75%); the middle value sits exactly at the limit.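

In this assay compound 4 gives > 50000 nM as a limit of the assay, not a number. Compound 3 has only the report "not toxic", so no step can be read between compound 3 and compound 4. Left open is where these compounds truly lie on the scale, and whether 2-bromo-4-fluorophenyl in place of tert-butyl changes the result at all.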